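A few compounds are considered here, and "the series" means these few. Any claim that something is new, unique, unknown or untested is made for them only; others in the source may bear on it.

In a functional assay (brain) with Canis familiaris (Canis lupus familiaris) as the target (a lower number here means a stronger inhibitor, a higher number a weaker inhibitor), compound 1 (`COC(CNc1ccccc1)CN1CCN(CCCC(c2ccc(F)cc2)c2ccc(F)cc2)CC1`) gives 15000 nM and compound 2 (`CN(CC(O)CN1CCN(CCCC(c2ccc(F)cc2)c2ccc(F)cc2)CC1)c1ccccc1`) gives 19000 nM. Going by the values given here, compound 2 therefore stands level with the only other measured compound, within the scatter. Compound 3 (`OC(CNCc1ccccc1)CN1CCN(CCCC(c2ccc(F)cc2)c2ccc(F)cc2)CC1`) has the same atoms as compound 2, joined differently: benzylamino in place of methyl(phenyl)amino on a saturated chain carbon, two bonds along the chain from an oxygen on a saturated carbon. The swap puts benzylamino in place of methyl(phenyl)amino on a saturated chain carbon, two bonds along the chain from an oxygen on a saturated carbon. Among the compounds with values here, only one measured step bears on this, a 1.3-fold higher number from compound 1 to compound 2 (0.10 log units; within the scatter). Within the data shown here, it altered the same side chain, but no measured pair shows this particular swap, so the evidence is thin. No step beyond the scatter is therefore expected in this assay, though the range must stay wide. The step expected from the estimate is a 1.4-fold lower number from compound 2 to compound 3 (0.13 log units; within the scatter). For compound 3 the estimated value is 14000 nM, within an expected range of 5000 nM to 40000 nM.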

Compound 3, half-maximal inhibitory concentration: 6900 nM
The estimate for compound 3 lay 2.0-fold (0.31 log units) above the measured number; the measured number falls inside the stated range.
By their numbers in this assay, from the lowest: compound 3; then compounds 1 and 2 (each within the scatter of the next).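

In this assay, going by these compounds alone, benzylamino in place of methyl(phenyl)amino gives a 2.8-fold lower number from compound 2 to compound 3 (0.44 log units; beyond the scatter), the first step beyond the scatter, even though the two compounds have the same atoms, joined differently. The side chain at this position can therefore change the number without any change in its atoms, though only modestly so far. The wider change to 2-(benzylamino)-1-hydroxyethyl in place of 2-anilino-1-methoxyethyl gives a 2.2-fold lower number from compound 1 to compound 3 (0.34 log units; beyond the scatter), and no measurement at hand explains either step.

From the compounds shown here alone, it remains open whether a benzyl(methyl)amino group would keep the lower number seen with benzylamino, which would separate the methyl group on the nitrogen from the extra carbon before the ring. Going by these compounds, it is also open whether a longer chain, as in 2-phenylethylamino, would lower the number further or raise it again.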